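Para substituent swap on the biaryl series: nitro to fluoro

The compounds below may be only part of what the source reports. "The series", "measured", "known", "first", "only" and "open" are said of these compounds alone.

Compound 1 `COc1cc(-n2cnc3ccc(-c4ccc([N+](=O)[O-])cc4)cc32)cc(OC)c1OC` is the most potent of the three measured compounds in a functional assay on MCF7 cells (Homo sapiens) for antiproliferative activity, read by MTT assay, with a stated time of 72 h (a lower number here means a stronger inhibitor, a higher number a weaker inhibitor), where compound 1 gives 740 nM. Compound 2 `COc1cc(-n2cnc3ccc(-c4cccc(F)c4)cc32)cc(OC)c1OC` gives 2350 nM and compound 3 `COc1cc(-n2cnc3ccc(-c4ccccc4)cc32)cc(OC)c1OC` gives 2290 nM; the two are indistinguishable, as shown by a 1.0-fold lower number from compound 2 to compound 3 (0.01 log units; within the scatter). Removing the nitro group costs potency: a 3.1-fold higher number from compound 1 to compound 3 (0.49 log units; beyond the scatter), and the same size of loss appears in a 3.2-fold higher number from compound 1 to compound 2 (0.50 log units; beyond the scatter).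

The next compound, compound 4 `COc1cc(-n2cnc3ccc(-c4ccc(F)cc4)cc32)cc(OC)c1OC`, differs from compound 1 by fluoro in place of nitro on an aromatic carbon. Among the measured compounds shown here, two measured steps bear on this. The loss of nitro in a 3.1-fold higher number from compound 1 to compound 3 (0.49 log units; beyond the scatter) suggests a modest weakening once nitro is gone, while a 1.0-fold lower number from compound 2 to compound 3 (0.01 log units; within the scatter) shows that a fluoro and a hydrogen on the aromatic ring give the same number, so the entering fluoro is not expected to restore what the nitro provided. Compound 4 is therefore expected to land near compound 3, with a step of a 2.7-fold higher number from compound 1 to compound 4 (0.43 log units; beyond the scatter), and an estimated value of 2000 nM in this assay, within the range 900 nM to 4500 nM.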

Compound 4, half-maximal inhibitory concentration: 1770 nM
The estimate for compound 4 lay 1.1-fold (0.05 log units) above the measured number, within the range that was stated.
By their numbers in this assay, from the lowest: compound 1; then compounds 4, 3 and 2 (each within the scatter of the next).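

In this assay the change from 4-nitrophenyl to 4-fluorophenyl gives a 2.4-fold higher number from compound 1 to compound 4 (0.38 log units; beyond the scatter) and adds a direct para comparison, so a fluoro at this place does not match the number of the nitro compound. At the same place, fluoro cannot be told apart from hydrogen in a 1.3-fold lower number from compound 3 to compound 4 (0.11 log units; within the scatter) and the shift from 3-fluorophenyl to 4-fluorophenyl is equally unresolved in a 1.3-fold lower number from compound 2 to compound 4 (0.12 log units; within the scatter) so that, of the compounds shown, only compound 1 stands apart from the others. No measurement at hand explains why the nitro compound stands apart.

From the compounds shown here alone, whether another group at this place, such as a nitrile, an amine or a carboxylic acid, would give a number like that of compound 1 remains open. Also open, going by these compounds, is whether the separation of compound 1 would hold in other cell lines.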